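The source may hold more compounds than are shown below. What is called first, only, known or untested is meant among the compounds shown, and "the series" means these compounds.

In a functional assay on MCF7 cells (Homo sapiens) for antiproliferative activity, read by sulforhodamine B assay, with a stated time of 48 h (on this read-out higher numbers stand for weaker inhibition and lower numbers for stronger inhibition), compound 1 (`COc1cc(C=C(C(=O)/C=C/c2cccc(OC)c2OC)C(=O)/C=C/c2cccc(OC)c2OC)cc(OC)c1O`) gives 460 nM and compound 2 (`COc1cc(OC)c(/C=C/C(=O)C(=Cc2ccc(O)c(F)c2)C(=O)/C=C/c2c(OC)cc(OC)cc2OC)c(OC)c1`) gives 3180 nM as the higher of the two numbers, a gap beyond the scatter. The change 4-hydroxy-3,5-dimethoxyphenyl in place of 3-fluoro-4-hydroxyphenyl on a double-bonded chain carbon bound to a double-bonded chain carbon turns compound 2 into compound 3 (`COc1cc(OC)c(/C=C/C(=O)C(=Cc2cc(OC)c(O)c(OC)c2)C(=O)/C=C/c2c(OC)cc(OC)cc2OC)c(OC)c1`). Going by the values given here, no measured step in this assay sizes this change, so only a moderate move toward a lower number is expected, with compound 1 at 460 nM as the sole lower reference. Compound 3 is estimated at 1500 nM (range 420 nM to 5000 nM). The expected move is a 2.1-fold lower number from compound 2 to compound 3 (0.33 log units; beyond the scatter) on this estimate.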

Compound 3, half-maximal inhibitory concentration: 1030 nM
Compound 3: the middle estimate sits 1.5-fold (0.16 log units) above what was measured; measured number inside the range.
By their numbers in this assay, from the lowest: compound 1; then compound 3; then compound 2.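

In this assay, the position on a double-bonded chain carbon bound to a double-bonded chain carbon now has its first sized change: 4-hydroxy-3,5-dimethoxyphenyl in place of 3-fluoro-4-hydroxyphenyl gives a 3.1-fold lower number from compound 2 to compound 3 (0.49 log units; beyond the scatter) on the shared core. The hydroxy group is present on both sides of this step, so the step does not test it. No measurement at hand accounts for the shift.

Still open, from the compounds shown here alone, is whether removing the hydroxy group or replacing it with an amine or a carboxylic acid would move the number. Going by these compounds alone, the single step also leaves open whether fluorine and the methoxy groups contribute separately.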